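Adding Methoxy Groups to a Styryl Sulfone Series

The compounds below may be only part of what the source reports. "The series", "measured", "known", "first", "only" and "open" are said of these compounds alone.

Compound 1 `COc1ccc(CS(=O)(=O)/C=C/c2ccc(F)cc2)cc1` is the starting point. In a functional assay on DLD-1 cells (Homo sapiens) for antiproliferative activity, read by trypan blue exclusion (a lower number here means a stronger inhibitor, a higher number a weaker inhibitor), compound 1 gives 2000 nM. Compound 2 `COc1ccc(CS(=O)(=O)/C=C/c2ccc(F)cc2OC)cc1` carries one extra group, (methoxy in place of hydrogen on an aromatic carbon), and in this assay compound 2 gives 15000 nM, so a 7.5-fold higher number from compound 1 to compound 2 (0.88 log units; beyond the scatter). Compound 3 `COc1ccc(CS(=O)(=O)/C=C/c2cc(OC)cc(OC)c2)cc1` has a different core, and the difference between the two cores is not broken down here. For compound 3 this assay reports only a limit, > 20000 nM, which is the limit of > 20000 nM in this assay, at which 1 of the 3 values shown sits. Compound 4 `COc1ccc(CS(=O)(=O)/C=C/c2cc(OC)c(OC)c(OC)c2)cc1` is still to be measured; it differs from compound 3 by methoxy in place of hydrogen on an aromatic carbon. This is the same kind of change as from compound 1 to compound 2, though the place differs: ortho to two methoxy groups and para to a large group, rather than ortho to a large group and meta to a fluoro group. Given that a 7.5-fold higher number from compound 1 to compound 2 (0.88 log units; beyond the scatter), and given the limit already seen for compound 3, for compound 4 a step that the limit leaves unreadable from compound 3 to compound 4 is expected, giving an estimated 30000 nM in this assay, quite possibly reported again only as a limit.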

Compound 4, half-maximal inhibitory concentration: > 20000 nM
Compound 4 was reported as a limit; the forecaster's own chance of this, stated with the estimate: 70%; the middle value is on the limit's open side.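

Compound 3 and compound 4 are both reported only as a limit, so the step between them cannot be read: the limit of > 20000 nM in this assay, at which 2 of the 4 values shown sit.

Going by these compounds, whether the added methoxy on compound 4 makes any difference in this assay stays open.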